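This account rests on a few compounds, and the source may have more. Where it says the series, first, only, none or still open, it means among the compounds named here.

Within the data shown here, compound 1 `COc1ccc2[nH]c(-c3ccc[nH]3)c(C3CC(=O)NC3=O)c2c1` is the only compound in this small set with an actual number: in a functional assay on OE21 cells (Homo sapiens) for cytotoxicity, read by MTT assay, with a stated time of 72 h (a higher number here means a weaker inhibitor, a lower number a stronger inhibitor), compound 1 gives 53000 nM as its half-maximal inhibitory concentration. For compound 2 `c1ccc2[nH]c(-n3cccn3)cc2c1` the reading of > 100000 nM is a limit of the assay and not a number. The compound to follow next is compound 3 `O=C1CC(c2c(-c3ccc[nH]3)[nH]c3ccccc23)C(=O)N1` which keeps the core of compound 1 and makes a single change: hydrogen in place of methoxy on an aromatic carbon with nothing else altered. Among the measured compounds shown here, no measured pair shows what this swap does, so no shift beyond the usual scatter is expected in this assay and neither direction is favoured. The estimate therefore amounts to an expected 1.1-fold higher number from compound 1 to compound 3 (0.05 log units; within the scatter) and no more. The expected value for compound 3 is 60000 nM with an estimated range from 22000 nM to 100000 nM around it.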

Compound 3, half-maximal inhibitory concentration: 67000 nM
Estimate against measurement, compound 3: 1.1-fold (0.05 log units) below; measured number inside the range.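

In this assay, putting hydrogen in place of methoxy on an aromatic carbon gives a 1.3-fold higher number from compound 1 to compound 3 (0.10 log units; within the scatter). Among these compounds, this is the only measured pair that tests this position, and it shows that the methoxy group is not required for the cytotoxicity seen here, since the two compounds cannot be told apart. The reading for compound 2 is a limit of the assay and not a number, so it offers no step to set beside this one: the limit of > 100000 nM in this assay, at which 1 of the 3 values shown sits.

Going by these compounds, a single swap says little about the position as a whole, so it remains open whether another group at this place, such as an amine or a carboxylic acid, would move the number beyond the scatter. Also open, on these data alone, is whether changes elsewhere on the shared core would matter more than this one.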